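Ester variation in a dihydropyrimidinone adenosine receptor series

This account rests on a few compounds, and the source may have more. Where it says the series, first, only, none or still open, it means among the compounds named here.

Measured so far:
compound 1 `CC1=C(C(=O)OCc2ccccc2)C(c2cccs2)NC(=O)N1` – 45%
compound 2 `CCCOC(=O)C1=C(C)NC(=O)NC1c1ccsc1` – 44%

In an assay on membranes from CHO cells for displacement of a labelled ligand from adenosine receptor A1 (Homo sapiens), read by scintillation counting, with a stated time of 60 min, tested at 1 uM (on this read-out higher numbers stand for more inhibition at the one concentration tested (going by the name of the read-out) and lower numbers for less inhibition), compound 1 gives 45% and compound 2 gives 44%. Compound 2 has the lowest of the two numbers, but its nearest neighbour, compound 1, sits only slightly higher, within the scatter, so no order between them can be read.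

Compound 3 `CC1=C(C(=O)OCc2ccccc2)C(c2ccsc2)NC(=O)N1` has not yet been measured. Its difference from compound 2 is phenyl in place of ethyl on a saturated chain carbon bound to an oxygen next to a carbonyl group. Going by the values given here, no pair of measured compounds differing in one place is available to size this change, and compound 1 and compound 2 differ in more than one place. With two near-identical numbers as the only reference, the step from compound 2 to compound 3 is expected to stay within the scatter, in no particular direction: a number 1 percentage points higher from compound 2 to compound 3 (within the scatter). For compound 3 the estimate is 45%, spanning 30% to 60%.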

Compound 3, a percentage reported as inhibition, at one concentration (the size of the read-out at that concentration, not a potency): 57%
Beside the measured number, compound 3's estimate is 12 percentage points below it, within the range that was stated.
By their numbers in this assay, from the lowest: compounds 2 and 1 (each within the scatter of the next); then compound 3.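

In this assay, going by these compounds alone, phenyl in place of ethyl on a saturated chain carbon bound to an oxygen next to a carbonyl group gives a number 13 percentage points higher from compound 2 to compound 3 (beyond the scatter), the first sized step at this position, with thiophen-3-yl held constant. With benzyl held constant, thiophen-3-yl in place of thiophen-2-yl on a saturated ring carbon gives a number 12 percentage points higher from compound 1 to compound 3 (beyond the scatter), so the near-equal numbers of compound 1 and compound 2 had concealed two separate one-place steps of similar size. No available data bear on the origin of either step.

Going by these compounds, each change rests on a single pair, so it remains open whether the step from propyl to benzyl also holds with thiophen-2-yl. On these data alone, how a longer chain such as hexyl, or an amine at the end of the chain, would compare with benzyl also remains open.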